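This account rests on a few compounds, and the source may have more. Where it says the series, first, only, none or still open, it means among the compounds named here.

Of the compounds shown here, two that share one core have been measured in a physicochemical assay for solubility, read by spectrophotometry, in phosphate buffer, with a stated time of 2 h, at pH 7.4; a higher number here means a more soluble compound, a lower number a less soluble compound. Compound 1, `COc1ccc2[nH]c(C(=O)N3CC(=O)N(Cc4ccccc4)[C@@H](CCc4ccccc4)C3)cc2c1`, gives 4400 nM in this assay. Compound 2, `COc1ccc2[nH]c(C(=O)N3CC(=O)N(c4ccccc4)[C@@H](Cc4ccccc4)C3)cc2c1`, gives 36100 nM in this assay. Compound 1 therefore stands at the lowest of the two numbers, with compound 2 as the nearest, and the gap between the two lies beyond the usual scatter. The two compounds differ in more than one place, so the gap cannot be credited to any single change.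

Compound 3, `COc1ccc2[nH]c(C(=O)N3CC(=O)N(Cc4ccccc4)[C@@H](CN4CCn5cccc5C4)C3)cc2c1`, has not yet been measured. It differs from compound 1 in one place: a group of 9 heavy atoms (7 carbon, 2 nitrogen; one five-membered aromatic ring with 1 hetero atom, one six-membered non-aromatic ring with 2 hetero atoms) in place of a group of 7 heavy atoms (7 carbon; one six-membered aromatic ring of carbon only), on a saturated chain carbon bound to a saturated ring carbon. Among the compounds with values here, no step between two measured compounds shows this change, so any expectation rests on compound 1 alone. The step from compound 1 to compound 3 is expected to be a moderate rise in solubility, larger than the scatter, at a 3.4-fold higher number from compound 1 to compound 3 (0.53 log units; beyond the scatter). Compound 3 is thus estimated at 15000 nM in this assay, with a range from 5000 nM to 50000 nM. Whether that expectation holds is what the measurement will tell.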

Compound 3, solubility: 29700 nM
Compound 3: the middle estimate sits 2.0-fold (0.30 log units) below what was measured; measured number inside the range.
By their numbers in this assay, from the lowest: compound 1; then compounds 3 and 2 (each within the scatter of the next).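

At the saturated chain carbon bound to a saturated ring carbon, replacing benzyl with the group that holds a five-membered aromatic ring and a six-membered non-aromatic ring comes with a 6.8-fold higher number from compound 1 to compound 3 (0.83 log units; beyond the scatter) in this assay. Within the data shown here, the gap between compound 1 and compound 2 spans more than one place, whereas this step gives a first reading of a change confined to one place, and it shows that the position can take a larger, nitrogen-bearing group with hydrogen-bond acceptors, where benzyl has none, without a fall in this number. No separate measurement bears on why the number moved.

This single step cannot separate the contributions of the two nitrogens, the changed rings and the extra heavy atoms, since all of them enter together. A simple amine such as piperidine, a carboxylic acid or a longer chain at this same place would help show which of those features travels with the step, and the same swap on a second core would show whether it holds beyond compound 1.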